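One Methyl More on a Chain Near Nitrogen

This account rests on a few compounds, and the source may have more. Where it says the series, first, only, none or still open, it means among the compounds named here.

Of the compounds shown here, three have been tested so far. Compound 3 `C/N=C(\S)NCCCCCCn1nc(-c2ccccc2)ccc1=O` and compound 1 `CC/N=C(\S)NCCCCCCn1nc(-c2ccccc2)ccc1=O` share a core and differ in one place: methyl in place of hydrogen on a saturated chain carbon bound to a double-bonded nitrogen. In a functional assay on the whole organism with Rattus norvegicus as the target, at a dose of 100 mg/kg (on this read-out higher numbers stand for more inhibition at the one dose given (going by the name of the read-out) and lower numbers for less inhibition), compound 3 gives 22.2%, and compound 1 gives -5.6%. Among the compounds with values here, that step, a number 27.8 percentage points lower from compound 3 to compound 1 (beyond the scatter), is the only measured example of this change. Compound 2 `C/N=C(/NC#N)NCCCn1nc(-c2ccccc2)c(C)cc1=O` is built on a different core; how its core differs from that of compound 3 is not broken down here. In this assay compound 2 gives 17.2%, a number that lies within the scatter of compound 3 and well apart from compound 1.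

Compound 4 `CC/N=C(/NC#N)NCCCn1nc(-c2ccccc2)c(C)cc1=O` has not yet been measured. It is compound 2 with the same change that turns compound 3 into compound 1: methyl in place of hydrogen on a saturated chain carbon bound to a double-bonded nitrogen. With one precedent only, the expectation rests on that single step: the step from compound 2 to compound 4 in this assay is expected to be a number 20.2 percentage points lower from compound 2 to compound 4 (beyond the scatter), because of a number 27.8 percentage points lower from compound 3 to compound 1 (beyond the scatter), although the two cores differ in ways not broken down here, so the same size is far from assured. Compound 4 is therefore expected to give about -3% in this assay. The plausible range for compound 4 is estimated to run from -25% to 18%.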

Compound 4, a percentage reported as inhibition, in the whole organism at one dose (the size of the read-out at that dose, not a potency): 0.2%
Estimate against measurement, compound 4: 3.2 percentage points below; the range from low to high includes it.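

In this assay, methyl in place of hydrogen on a saturated chain carbon bound to a double-bonded nitrogen again goes with a drop, a number 17 percentage points lower from compound 2 to compound 4 (beyond the scatter), and this step can be set beside the earlier one on the other core: the same change on two cores in this assay, a number 27.8 percentage points lower (beyond the scatter) from compound 3 to compound 1 and a number 17 percentage points lower (beyond the scatter) from compound 2 to compound 4, 10.8 percentage points apart, within the scatter of two such steps In these two pairs, then, the change carried over from one core to the other, pointing the same way each time and with a size that cannot be told apart given the usual scatter. This does not show that the change would behave alike on any other core in the series, since two pairs are a very small sample, the two cores differ in ways not broken down here, and each number is the size of an effect at a single dose rather than a potency.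

The compounds shown stop at the ethyl group that this change creates, so it remains open whether a longer chain such as propyl would lower the number further or leave it where it is. Also open, from the compounds shown here alone, is how a chain carrying an amine or a carboxylic acid at this place would read out in this assay.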